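The source may report more compounds than this note shows. Statements on the series, on what has been measured and on what is new or still open speak of the compounds shown alone.

Measured compounds:
- compound 1, `COc1ccc(Oc2ccc(N3CC(=O)N([C@@H](CC4CCN(C(=O)C(C)C)CC4)c4nc5ccc(C)cc5n4C)C3=O)cc2)cc1`, in an ADME assay on the whole organism (Rattus norvegicus, strain Sprague-Dawley) for pharmacokinetics, read by LC-MS, with a stated time of 360 min, at a dose of 30 mg/kg by the oral route (on this read-out higher numbers stand for higher oral bioavailability and lower numbers for lower oral bioavailability), compound 1 gives 18%
- compound 2, `CC(C)C(=O)N1CCC(C[C@@H](c2nc3ccc(F)cc3n2C2CC2)N2C(=O)CN(c3ccc(Oc4ccc(F)cc4)cc3)C2=O)CC1`, in this assay compound 2 gives 55.4%

Compound 2 stands highest of the two numbers. Its nearest neighbour, compound 1, lies lower by a gap that is beyond the usual scatter of this measurement. Compound 1 and compound 2 differ in several places at once, so that gap cannot be tied to any single change.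

Compound 3, `Cc1ccc2nc([C@H](CC3CCN(C(=O)C(C)C)CC3)N3C(=O)CN(c4ccc(Oc5ccc(F)cc5)cc4)C3=O)n(C3CC3)c2c1`, has not yet been measured. It differs from compound 2 in one place only: methyl in place of fluoro on an aromatic carbon. For the measured compounds named here, no pair of measured compounds shows what this swap alone does in this assay, so the direction is open. The step is expected to be small, a number 10.4 percentage points lower from compound 2 to compound 3 (beyond the scatter), and likely within the scatter. Compound 3 is therefore estimated at 45%, with a plausible range from 20% to 70%.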

Compound 3, oral bioavailability: 32.4%
Compound 3: middle estimate off by 12.6 percentage points, on the high side, within the range that was stated.
By their numbers in this assay, from the lowest: compound 1; then compound 3; then compound 2.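

For the compounds shown here, the pair of compound 2 and compound 3 is the first here that differs in one place only, so it isolates a single change. In this assay methyl in place of fluoro on this aromatic carbon gives a number 23 percentage points lower from compound 2 to compound 3 (beyond the scatter) and settles the direction that was open: at this position, fluoro goes with the higher oral bioavailability. The swap exchanges one heavy atom for another and changes no count of hydrogen-bond donors, acceptors or net charge, yet the data offer no measured explanation for the step.

As far as these compounds go, whether a chloro group, a nitrile or an amine at this position would fall nearer compound 2 or compound 3 remains open. Compound 1 differs from compound 3 in more than one place, so its number cannot be tied to this position.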